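Removing the methoxy from the aryl ether of compound 3

A few compounds are considered here, and "the series" means these few. Any claim that something is new, unique, unknown or untested is made for them only; others in the source may bear on it.

Measured so far:
compound 1 `c1ccc(Oc2ccc3c(NCCCNCc4ccco4)ccnc3c2)cc1`: 317 10^-6 cm/s
compound 2 `COc1cccc(CNCCCNc2ccnc3cc(Oc4ccc(Cl)cc4)ccc23)c1O`: 317 10^-6 cm/s
compound 3 `COc1cccc(Oc2ccc3c(NCCCNCc4cccc(OC)c4O)ccnc3c2)c1`: 317 10^-6 cm/s

In an ADME assay for permeability, using PAMPA, with a stated time of 30 min, at pH 7.4 (a higher number here means that the compound crosses the layer faster, a lower number that the compound crosses the layer more slowly), compound 3 gives 317 10^-6 cm/s, level with compound 1, which gives 317 10^-6 cm/s, and with compound 2, which gives 317 10^-6 cm/s. Going by the values given here, the one step measured between these compounds, from compound 2 to compound 3, was no change at the digits printed from compound 2 to compound 3 (within the scatter), so exchanging the group on the aryl ether oxygen left this assay unmoved.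

Compound 4 `COc1cccc(CNCCCNc2ccnc3cc(Oc4ccccc4)ccc23)c1O` has not yet been measured in this assay. It differs from compound 3 by hydrogen in place of methoxy on an aromatic carbon.

Among the compounds with values here, no measured pair covers exactly this change. What bears on it is the step from compound 2 to compound 3, in which a different group on the same ether oxygen gave no shift, and the fact that compound 1, which carries an unsubstituted phenoxy like compound 4, stands level with compounds 2 and 3. On this basis no step beyond the scatter is expected in this assay for compound 4: the estimated step is no change at the digits printed from compound 3 to compound 4 (within the scatter). Compound 4 is therefore expected to give about 317 10^-6 cm/s, with a range from 180 10^-6 cm/s to 520 10^-6 cm/s.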

Compound 4, apparent permeability: 317 10^-6 cm/s
Beside the measured number, compound 4's estimate shows no gap at the digits printed; low and high end bracket the measured number.
By their numbers in this assay, from the lowest: compounds 1, 2, 3 and 4 (each within the scatter of the next).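

In this assay, the methoxy on the aryl ether proves dispensable for this read-out: taking it away gave no change at the digits printed from compound 3 to compound 4 (within the scatter), and hydrogen in place of chloro at the same aryl ether gave no change at the digits printed from compound 2 to compound 4 (within the scatter) as well, so the plain phenoxy, the 3-methoxyphenoxy and the chlorinated phenoxy of compound 2 cannot be told apart here. Going by these compounds alone, compound 4 also supplies the first one-place comparison at the other end of the molecule, since 2-hydroxy-3-methoxyphenyl in place of furan-2-yl on a saturated chain carbon bound to an amine nitrogen gave no change at the digits printed from compound 1 to compound 4 (within the scatter). Compounds 1 and 2 differ from each other in two places. The data offer no measured explanation for why all four compounds print the same number.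

Going by these compounds, whether this flat picture holds for groups of another kind on the phenoxy, such as a carboxylic acid or a primary amine, stays open, and so does the effect of a longer chain between the two nitrogens of the shared core. Four compounds that print the same number also cannot show how far this assay would respond to any change at these places.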